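Trading pyridin-4-yl for furan-2-yl on the amide

The source may report more compounds than this note shows. Statements on the series, on what has been measured and on what is new or still open speak of the compounds shown alone.

Of the compounds shown here, two with the same core have been tested in a functional assay on NCI-H460 cells (Homo sapiens) for cytotoxicity; on this read-out higher numbers stand for weaker inhibition and lower numbers for stronger inhibition. Compound 1 `COc1ccc(S(=O)(=O)N2CCc3cccc(NC(=O)c4ccc([N+](=O)[O-])cc4)c32)cc1` gives 122 nM, while compound 2 `COc1ccc(S(=O)(=O)N2CCc3cccc(NC(=O)c4ccncc4)c32)cc1` gives 9.4 nM, the lower of the two numbers and therefore the stronger inhibition. Within the data shown here, only one measured step bears on what comes next: a 13-fold lower number from compound 1 to compound 2 (1.11 log units; beyond the scatter). This large step came from pyridin-4-yl in place of 4-nitrophenyl on a carbonyl carbon, the same place that changes now.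

Compound 3 `COc1ccc(S(=O)(=O)N2CCc3cccc(NC(=O)c4ccco4)c32)cc1` carries furan-2-yl in place of pyridin-4-yl on a carbonyl carbon. Among the measured compounds shown here, no furan-2-yl compound has been measured yet, so the earlier step indicates how far a change at this place can move the number, but not which way this new change will go. With compound 2 already at 9.4 nM, a moderate rise seems more likely than a further fall. The expected change is a 3.2-fold higher number from compound 2 to compound 3 (0.50 log units; beyond the scatter), a smaller move than the earlier one. For compound 3, the estimated value is 30 nM, with an expected range of 8 nM to 120 nM.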

Compound 3, half-maximal inhibitory concentration: 9.8 nM
Compound 3: the middle estimate sits 3.1-fold (0.49 log units) above what was measured; the range from low to high includes it.
By their numbers in this assay, from the lowest: compounds 2 and 3 (each within the scatter of the next); then compound 1.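

In this assay, the place on the carbonyl carbon takes a five-membered aromatic ring with one oxygen as well as a six-membered aromatic ring with one nitrogen, with a 1.0-fold higher number from compound 2 to compound 3 (0.02 log units; within the scatter). Among these compounds, the large step seen earlier is therefore not unique to pyridin-4-yl, since furan-2-yl in the same place gives a 12-fold lower number from compound 1 to compound 3 (1.10 log units; beyond the scatter), which leaves 4-nitrophenyl as the only group of the three with a clearly higher number. Nothing available explains why the two smaller rings match or why 4-nitrophenyl stands apart.

On these data alone, it remains open whether an aromatic ring is needed here at all, a question that a saturated ring such as piperidin-4-yl or an open chain such as acetyl on the same carbonyl carbon could answer. Plain phenyl would show whether the higher number of the 4-nitrophenyl compound goes with the nitro group or with the benzene ring itself, and thiophen-2-yl would show whether the oxygen of furan-2-yl can be exchanged for sulfur.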